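This account rests on a few compounds, and the source may have more. Where it says the series, first, only, none or still open, it means among the compounds named here.

Series measured in a functional assay on SKW3 cells (Homo sapiens) for antiproliferative activity, read by WST assay, with a stated time of 3 days; on this read-out lower numbers stand for stronger inhibition and higher numbers for weaker inhibition:

- compound 1 `O=c1cc(I)n([C@@H]2O[C@H](CO)[C@@H](O)[C@H]2O)c(=O)[nH]1`: 18900 nM
- compound 2 `O=c1[nH]c(=O)n([C@@H]2O[C@H](CO)[C@@H](O)[C@H]2O)c(I)c1F`: > 50000 nM (a limit of the assay, not a number)
- compound 3 `Nc1c(F)c(=O)[nH]c(=O)n1[C@@H]1O[C@H](CO)[C@@H](O)[C@H]1O`: 600 nM

Compound 2 stands only at its limit of > 50000 nM, so any step from it starts from an open end.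

Compound 4 `O=c1[nH]c(=O)n([C@@H]2O[C@H](CO)[C@@H](O)[C@H]2O)c(I)c1Br` is not yet measured. It differs from compound 2 by bromo in place of fluoro on an aromatic carbon, ortho to an iodo group (bromo in place of fluoro on an aromatic carbon). Among the measured compounds shown here, no measured step introduces bromo.

The closest evidence is an at least 2.6-fold higher number from compound 1 to compound 2 (0.42 log units; beyond the scatter), at least modest, for fluoro in place of hydrogen at the same carbon. The large at least 83-fold lower number from compound 2 to compound 3 (1.92 log units; beyond the scatter) replaces the iodo group, which compound 4 keeps, so it bears little on this change.

With the iodo group retained, a gain like that of compound 3 is not expected, and no step beyond the scatter is expected in this assay. The expected step is a number no higher from compound 2 to compound 4 (the limit leaves the size open). For compound 4 the estimated value is 50000 nM, with an expected range from 15000 nM to 120000 nM.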

Compound 4, half-maximal inhibitory concentration: > 50000 nM
Compound 4 was reported as a limit; the forecaster's own chance of this, stated with the estimate: 55%; the middle value lies on the limit itself.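

In this assay, bromo in place of hydrogen on this carbon gives an at least 2.6-fold higher number from compound 1 to compound 4 (0.42 log units; beyond the scatter), so the loss seen with fluoro is not confined to fluoro. Compound 4 is reported only as a limit, > 50000 nM. The step between compound 2 and compound 4 cannot be read, and fluoro and bromo cannot be ranked here because both compounds sit at the same limit: the limit of > 50000 nM in this assay, at which 2 of the 4 values shown sit.

Still open, from the compounds shown here alone, is whether a methyl or a nitrile on this carbon, with the iodo group kept, would give a readable value in this assay. Also open, going by these compounds, is whether bromo is tolerated once amino replaces the iodo group, the change that brings compound 3 to 600 nM.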